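Notes on the step from compound 3 to compound 4

This account rests on a few compounds, and the source may have more. Where it says the series, first, only, none or still open, it means among the compounds named here.

In a physicochemical assay for solubility, with a stated time of 24 h, tested at 30 mg/mL (a lower number here means a less soluble compound, a higher number a more soluble compound), compound 1 (`CC(=O)N1CC2(C1)CC(NS(=O)(=O)c1ccc(OCc3cc(C)nc4ccccc34)cc1)(C(=O)NO)C2`) gives 17000000 nM and compound 2 (`Cc1cc(COc2ccc(S(=O)(=O)NCCC(=O)NO)cc2)c2ccccc2n1`) gives 4100000 nM in the same measurement. Compound 3 (`Cc1cc(COc2ccc(S(=O)(=O)NC3(CC(=O)NO)CC3)cc2)c2ccccc2n1`) gives 1600000 nM as the lowest of the three numbers, and the higher value of compound 1 lies furthest from it.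

The change to compound 4 (`Cc1cc(COc2ccc(S(=O)(=O)NCC(=O)NO)cc2)c2ccccc2n1`) is a group of 5 heavy atoms (2 carbon, 1 nitrogen, 2 oxygen; no ring) in place of a group of 8 heavy atoms (5 carbon, 1 nitrogen, 2 oxygen; one three-membered non-aromatic ring of carbon only), on a sulfonamide nitrogen in which (hydroxycarbamoyl)methyl now sits on a sulfonamide nitrogen and the three-membered ring of carbon is gone.

Going by the values given here, one measured step bears on this place: a 2.6-fold lower number from compound 2 to compound 3 (0.41 log units; beyond the scatter) is modest, and it comes with the gain of that same ring. Undoing the ring therefore points to a higher number, of about that size. That reading stays loose. Compound 1 goes against any simple rule on rings, as it also carries rings on that nitrogen and holds the highest number. Among the compounds with values here, no measured compound carries (hydroxycarbamoyl)methyl at this nitrogen, so the expectation rests on one step only.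

The expected change in this assay is a 2.2-fold higher number from compound 3 to compound 4 (0.34 log units; beyond the scatter) as a modest rise. For compound 4 the estimate is 3500000 nM (expected range 1500000 nM to 9000000 nM).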

Compound 4, solubility: 100000 nM
Compound 4: the middle estimate sits 35-fold (1.54 log units) above what was measured; the whole stated range lies above it.
By their numbers in this assay, from the lowest: compound 4; then compound 3; then compound 2; then compound 1.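

In this assay, (hydroxycarbamoyl)methyl on a sulfonamide nitrogen gives the lowest number of the series, and both steps into it are large: a 16-fold lower number from compound 3 to compound 4 (1.20 log units; beyond the scatter) with loss of the three-membered ring of carbon, and a 41-fold lower number from compound 2 to compound 4 (1.61 log units; beyond the scatter) with hydroxycarbamoyl in place of (hydroxycarbamoyl)methyl on a saturated chain carbon bound to a sulfonamide nitrogen. Going by these compounds alone, the ring alone therefore does not set the direction at this position, since compound 3 lies between two compounds without a ring, compound 2 and compound 4, and the sharp drop on shortening the chain was not visible in the earlier compounds. Group size gives only a partial order, as compound 4 carries the smallest group and compound 1 the largest, while compound 3 goes against that order by lying below compound 2, and no supporting measurement is available to account for these differences.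

Going by these compounds, it remains open how a longer chain ending in hydroxycarbamoyl would stand on this sulfonamide nitrogen in this assay. Also open, on these data alone, is whether a carboxylic acid or an amine in place of hydroxycarbamoyl would follow the same order across these chains.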